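Swapping Methoxy for Phenyl Across Two Related Cores

This account rests on a few compounds, and the source may have more. Where it says the series, first, only, none or still open, it means among the compounds named here.

Compound 1 `COc1ccc(NC(=O)COc2c(-c3ccccc3)oc3ccccc3c2=O)cc1` and compound 3 `COc1ccc(NC(=O)COc2ccc3c(=O)cc(-c4ccccc4)oc3c2)cc1` are built from the same atoms joined differently; the difference between the two cores is not broken down here. In a functional assay on NCI-H661 cells (Homo sapiens) for antiproliferative activity, read by MTT assay, with a stated time of 72 h (a higher number here means a weaker inhibitor of growth, a lower number a stronger inhibitor of growth), compound 1 gives 6740 nM. In this assay compound 3 gives 5500 nM, a value within the usual scatter of that of compound 1. Compound 2 `O=C(COc1c(-c2ccccc2)oc2ccccc2c1=O)Nc1ccc(-c2ccccc2)cc1` differs from compound 1 by phenyl in place of methoxy on an aromatic carbon. In this assay compound 2 reaches only a limit of the assay, > 10000 nM. That change produced an at least 1.4-fold higher number from compound 1 to compound 2 (0.17 log units; that floor lies within the scatter), and what is known of its size is bounded by the limit of > 10000 nM in this assay, at which 1 of the 3 values shown sits.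

Compound 4 `O=C(COc1ccc2c(=O)cc(-c3ccccc3)oc2c1)Nc1ccc(-c2ccccc2)cc1`, not yet measured, differs from compound 3 by phenyl in place of methoxy on an aromatic carbon, the same change as seen between compound 1 and compound 2, now made on the core of compound 3. The step from compound 3 to compound 4 is expected to be a 2.2-fold higher number from compound 3 to compound 4 (0.34 log units; beyond the scatter), resting on the measured step of an at least 1.4-fold higher number from compound 1 to compound 2 (0.17 log units; that floor lies within the scatter). Compound 4 is therefore estimated to give 12000 nM in this assay, within a range of 5000 nM to 30000 nM, and the assay may again report only a limit.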

Compound 4, concentration for 50% growth inhibition: 1280 nM
Compound 4: the middle estimate sits 9.4-fold (0.97 log units) above what was measured, outside the stated range (below it).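

Made on the second core, phenyl in place of methoxy on an aromatic carbon produced a 4.3-fold lower number from compound 3 to compound 4 (0.63 log units; beyond the scatter) in this assay. The same change therefore did not carry over unchanged from one core to the other, and in this series its outcome differed with the core that bore it: the same change on two cores in this assay, an at least 1.4-fold higher number (0.17 log units; that floor lies within the scatter) from compound 1 to compound 2 and a 4.3-fold lower number (0.63 log units; beyond the scatter) from compound 3 to compound 4, at least 6.3-fold (0.80 log units) apart, beyond the scatter of two such steps. As far as these compounds go, compound 2 stands at a limit of the assay and not at a number, so the true size of the step on the first core stays unknown, and a single pair on each core gives no rule for any further core: the limit of > 10000 nM in this assay, at which 1 of the 4 values shown sits.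

The compounds shown leave open whether the difference between the two steps also appears with other groups in the same place, such as a chlorine atom, a dimethylamino group or a benzyloxy group. They also leave open whether a longer chain joining the core to the amide would alter the result on either core.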